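Compound 4 in the cytotoxicity series: aminomethyl to aryl-ethenyl

The compounds below may be only part of what the source reports. "The series", "measured", "known", "first", "only" and "open" are said of these compounds alone.

For the measured compounds named here, compound 3 `NCc1nnc(-c2cc(S(N)(=O)=O)c(SCc3ccccc3)cc2Cl)o1` gives 490000 nM in a functional assay on HeLa cells (Homo sapiens) for cytotoxicity, read by MTT assay, with a stated time of 72 h (on this read-out higher numbers stand for weaker inhibition and lower numbers for stronger inhibition), the highest of the three numbers measured so far. Compound 1 `NS(=O)(=O)c1cc(-c2nnc(CN3CCN(c4ccccc4)CC3)o2)c(Cl)cc1SCc1ccccc1` gives 100000 nM and compound 2 `NS(=O)(=O)c1cc(-c2nnc(Cn3cc(-c4ccccc4)nn3)o2)c(Cl)cc1SCc1ccccc1` gives 7000 nM in this assay. Both of these carry a larger ring-bearing group where compound 3 carries the amino group: the step of a 4.9-fold higher number from compound 1 to compound 3 (0.69 log units; beyond the scatter) and the step of a 70-fold higher number from compound 2 to compound 3 (1.85 log units; beyond the scatter) both run toward higher numbers when the amino group replaces the ring-bearing one, and a 14-fold lower number from compound 1 to compound 2 (1.15 log units; beyond the scatter) shows that the choice of ring-bearing group itself matters considerably.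

Compound 4 `NS(=O)(=O)c1cc(-c2nnc(/C=C/c3cccc(Cl)c3)o2)c(Cl)cc1SCc1ccccc1` differs from compound 3 by 2-(3-chlorophenyl)ethenyl in place of aminomethyl on an aromatic carbon. This change likewise exchanges a small group for a larger ring-bearing one, though at the aromatic carbon of the core rather than on a chain carbon, so the two measured steps bear on it by analogy only. A lower number is therefore expected for compound 4, by a step of a 16-fold lower number from compound 3 to compound 4 (1.21 log units; beyond the scatter) in this assay. Compound 4 is estimated at 30000 nM, with a range from 5000 nM to 150000 nM.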

Compound 4, half-maximal inhibitory concentration: 16000 nM
For compound 4 the middle estimate is 1.9-fold (0.27 log units) above the measured one, and the stated range covers the measured number.
By their numbers in this assay, from the lowest: compound 2; then compound 4; then compound 1; then compound 3.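

Replacing aminomethyl at this carbon with 2-(3-chlorophenyl)ethenyl gives a 31-fold lower number from compound 3 to compound 4 (1.49 log units; beyond the scatter) in this assay, so a group with a double bond outside aromatic rings and no hydrogen-bond donor is tolerated here, and the ring-bearing group need not be attached through a saturated chain carbon or contain a nitrogen. The step of a 2.3-fold higher number from compound 2 to compound 4 (0.36 log units; beyond the scatter) shows that 2-(3-chlorophenyl)ethenyl and (4-phenyl-1H-1,2,3-triazol-1-yl)methyl are not equivalent at this position, although this gap is modest beside the step away from aminomethyl. No supporting data are available to explain either step.

The contributions of the chlorine and the double bond remain unseparated, and a comparison of the unsubstituted 2-phenylethenyl group with the saturated 2-(3-chlorophenyl)ethyl chain would address this. Going by these compounds, how a carboxylic acid at this carbon would behave also remains open.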